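A Methyl Cap on One Hydroxy Group

The source may hold more compounds than are shown below. What is called first, only, known or untested is meant among the compounds shown, and "the series" means these compounds.

In a functional assay on MCF7 cells (Homo sapiens) for inhibition, read by sulforhodamine B assay, with a stated time of 48 h (a lower number here means a stronger inhibitor of growth, a higher number a weaker inhibitor of growth), compound 1 (`O=C(Nc1cccc(-n2cc(-c3ccncc3)c(-c3ccc(Cl)c(O)c3)n2)c1)Nc1cccc(C(F)(F)F)c1`) gives 1340 nM as its result. Compound 2 (`COc1cc(-c2nn(-c3cccc(NC(=O)Nc4cc(C(F)(F)F)cc(C(F)(F)F)c4)c3)cc2-c2ccncc2)ccc1Cl`) gives 933 nM in this assay and compound 3 (`COc1cc(-c2nn(-c3cccc(NC(=O)Nc4ccc(Cl)c(Cl)c4)c3)cc2-c2ccncc2)ccc1Cl`) gives 945 nM there too. All three values lie within the usual scatter of one another, so compound 1 cannot be told apart from the other two.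

Compound 4 (`COc1cc(-c2nn(-c3cccc(NC(=O)Nc4cccc(C(F)(F)F)c4)c3)cc2-c2ccncc2)ccc1Cl`) differs from compound 1 in one place: methyl in place of hydrogen on an oxygen on an aromatic ring. This turns hydroxy into methoxy, and 4-chloro-3-hydroxyphenyl into 4-chloro-3-methoxyphenyl.

Within the data shown here, no measured pair shows this change alone. Even so, compound 2 at 933 nM and compound 3 at 945 nM already carry the 4-chloro-3-methoxyphenyl group, with other differences elsewhere, and both sit within the scatter of compound 1. No step beyond the scatter is therefore expected in this assay for this change. The estimated step is a 1.3-fold lower number from compound 1 to compound 4 (0.13 log units; within the scatter) and would stay within the scatter. For compound 4 the estimate is 1000 nM and the expected range runs from 500 nM to 2100 nM at the top.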

Compound 4, concentration for 50% growth inhibition: 751 nM
Compound 4: the middle estimate sits 1.3-fold (0.12 log units) above what was measured; low and high end bracket the measured number.
By their numbers in this assay, from the lowest: compounds 4, 2, 3 and 1 (each within the scatter of the next).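

Compound 1 and compound 4 differ only at this oxygen, so the methyl cap can now be read on its own: it gives a 1.8-fold lower number from compound 1 to compound 4 (0.25 log units; within the scatter) in this assay, and hydroxy and methoxy cannot be told apart here. Compound 4 also completes the comparison on the other side of the molecule: 3-(trifluoromethyl)phenyl in place of 3,4-dichlorophenyl gives a 1.3-fold lower number from compound 3 to compound 4 (0.10 log units; within the scatter), and hydrogen in place of trifluoromethyl gives a 1.2-fold lower number from compound 2 to compound 4 (0.09 log units; within the scatter), so these changes likewise show no step beyond the scatter. Nothing available bears on why these numbers stay so close.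

As far as these compounds go, what a larger group on this oxygen, such as ethyl or a longer chain, would do in this assay remains open. So does the result of putting an amine or a carboxylic acid in place of the hydroxy group.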